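Removing the para-chlorine from a triazole-linked steroid sulfonate

A few compounds are considered here, and "the series" means these few. Any claim that something is new, unique, unknown or untested is made for them only; others in the source may bear on it.

Three close relatives of one shared core have been tested in a functional assay on MCF7 cells (Homo sapiens) for cytotoxicity, read by MTT assay, with a stated time of 4 days; on this read-out lower numbers stand for stronger inhibition and higher numbers for weaker inhibition. Compound 1 `Cc1ccc(S(=O)(=O)Oc2ccc3c(c2C)[C@H](Cn2cc(-c4ccc(Br)cc4)nn2)[C@@]24CC(=O)[C@@](C)(CC[C@@H]32)C4)cc1` carries a bromo group on the phenyl ring attached to the triazole; in this assay compound 1 gives only a limit, > 20000 nM. Compound 2 `Cc1ccc(S(=O)(=O)Oc2ccc3c(c2C)[C@H](Cn2cc(-c4ccc(F)cc4)nn2)[C@@]24CC(=O)[C@@](C)(CC[C@@H]32)C4)cc1` carries a fluoro group in the same place; in this assay compound 2 again gives only a limit, > 20000 nM. Compound 3 `Cc1ccc(S(=O)(=O)Oc2ccc3c(c2C)[C@H](Cn2cc(-c4ccc(Cl)cc4)nn2)[C@@]24CC(=O)[C@@](C)(CC[C@@H]32)C4)cc1` carries a chloro group there; in this assay compound 3 likewise gives only a limit, > 20000 nM.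

Because all three values sit at the limit of > 20000 nM in this assay, at which 3 of the 3 values shown sit, the steps between them cannot be sized: a step that the two limits leave unreadable from compound 1 to compound 2, a step that the two limits leave unreadable from compound 1 to compound 3 and a step that the two limits leave unreadable from compound 2 to compound 3 are each unreadable. Compound 3 therefore stands exactly where its two relatives stand, at the limit.

Compound 4 `Cc1ccc(S(=O)(=O)Oc2ccc3c(c2C)[C@H](Cn2cc(-c4ccccc4)nn2)[C@@]24CC(=O)[C@@](C)(CC[C@@H]32)C4)cc1` takes the next step. hydrogen in place of chloro on an aromatic carbon

Within the data shown here, no measured step speaks to this change, since every neighbour of compound 3 returned a limit. The expectation for compound 4 is therefore the same outcome: an estimated value of 30000 nM, within a range from 10000 nM to 100000 nM, most probably reported again as a limit. The step this estimate implies from compound 3 is a step that the limit leaves unreadable from compound 3 to compound 4.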

Compound 4, half-maximal inhibitory concentration: > 20000 nM
Compound 4 gave a limit, no number; the forecaster's own chance of this, stated with the estimate: 85%; the middle value lies beyond the limit too.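

Compound 4 joins compound 1, compound 2 and compound 3 in giving only a limit rather than a number, so none of the steps among these compounds can be read in this assay: the limit of > 20000 nM in this assay, at which 4 of the 4 values shown sit.

The compounds shown leave open whether chloro, bromo, fluoro or hydrogen at this place on the phenyl ring makes any difference in this assay.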